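The Dimethylphenyl Variant of Compound 1: An Expected Potency

A few compounds are considered here, and "the series" means these few. Any claim that something is new, unique, unknown or untested is made for them only; others in the source may bear on it.

Compound 1 `NC1=NC2(CCOCC2)N(OCCCOc2ccc(F)cc2)C(N)=N1` carries a 4-fluorophenyl on the oxygen of its side chain. As far as these compounds go, in a functional assay on MDA-MB-231 cells (Homo sapiens) for antiproliferative activity, read by MTT assay, with a stated time of 72 h (a higher number here means a weaker inhibitor, a lower number a stronger inhibitor), compound 1 gives "not determined" (no result reported), so no number fixes where it stands, and its place on the scale remains open. For the measured compounds named here, the only guide comes from two compounds built on a different core. Compound 2 `NC1=NC2(CCSCC2)N(OCCCOc2cccc(Cl)c2Cl)C(N)=N1` gives 1 nM in this assay, and compound 3 `NC1=NC2(CCSCC2)N(OCCCOc2cc(Cl)c(Cl)cc2Cl)C(N)=N1` gives 110 nM. Going by the values given here, the single step between them, a 110-fold higher number from compound 2 to compound 3 (2.04 log units; beyond the scatter), shows that a change in the substitution of that ring alone can shift the read-out a long way.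

Compound 4 `Cc1cc(C)cc(OCCCON2C(N)=NC(N)=NC23CCOCC3)c1` differs from compound 1 in just this part of the molecule: 3,5-dimethylphenyl in place of 4-fluorophenyl on an oxygen on a saturated carbon. Among the compounds with values here, no measured step pairs these two groups, so the direction of the change cannot be read from the data; the step from compound 2 to compound 3 says only that a swap of this kind may be large. The scale is anchored by compound 2 at 1 nM and by compound 3 at 110 nM. On that basis compound 4 is expected to land at about 30 nM in this assay, with an estimated range from 3 nM to 500 nM.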

Compound 4, half-maximal inhibitory concentration: 3570 nM
Compound 4: the middle estimate sits 120-fold (2.08 log units) below what was measured, outside the stated range (above it).
By their numbers in this assay, from the lowest: compound 2; then compound 3; then compound 4.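

For the compounds shown here, compound 4 adds no new step: compound 1, the one compound that differs from it in a single place, has no number in this assay, so the swap between them cannot be read. The compounds shown leave open how 3,5-dimethylphenyl and 4-fluorophenyl compare on the shared core. Nothing else given here bears on the result.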